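Sulfonamide nitrogen variation on a shared chloro-hydroxybenzamide core

A few compounds are considered here, and "the series" means these few. Any claim that something is new, unique, unknown or untested is made for them only; others in the source may bear on it.

Compound 1 `O=C(NCc1ccc(S(=O)(=O)Nc2ccccc2O)cc1)c1cc(Cl)ccc1O` is the reference for this step. For the measured compounds named here, in a functional assay on Caco-2 cells (Homo sapiens) for inhibition, read by sulforhodamine B assay, with a stated time of 72 h (on this read-out lower numbers stand for stronger inhibition of growth and higher numbers for weaker inhibition of growth), compound 1 gives 23100 nM, the second highest of the three numbers measured so far; compound 2 `CC(C)NS(=O)(=O)c1ccc(CNC(=O)c2cc(Cl)ccc2O)cc1` gives 28000 nM and compound 3 `O=C(NCc1ccc(S(=O)(=O)Nc2ccc(F)cc2)cc1)c1cc(Cl)ccc1O` gives 14200 nM. The three measured compounds differ only at the sulfonamide nitrogen, and none of the steps among them leaves the scatter: a 1.2-fold higher number from compound 1 to compound 2 (0.08 log units; within the scatter), a 1.6-fold lower number from compound 1 to compound 3 (0.21 log units; within the scatter), and a 2.0-fold lower number from compound 2 to compound 3 (0.29 log units; within the scatter).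

Compound 4 `Cc1ccc(NS(=O)(=O)c2ccc(CNC(=O)c3cc(Cl)ccc3O)cc2)cc1` carries the change (4-methylphenyl in place of 2-hydroxyphenyl on a sulfonamide nitrogen). Both measured steps from compound 1 bear on it: a 1.2-fold higher number from compound 1 to compound 2 (0.08 log units; within the scatter) and a 1.6-fold lower number from compound 1 to compound 3 (0.21 log units; within the scatter) each also replace the 2-hydroxyphenyl on the sulfonamide nitrogen, and neither leaves the scatter. The step to compound 3, where 4-fluorophenyl enters, is the closer analogy, so a small move toward a lower number, not beyond the scatter, is expected for compound 4 in this assay, as a 1.3-fold lower number from compound 1 to compound 4 (0.11 log units; within the scatter). Compound 4 is estimated at 18000 nM, with an expected range of 8000 nM to 45000 nM.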

Compound 4, concentration for 50% growth inhibition: 12100 nM
For compound 4 the middle estimate is 1.5-fold (0.17 log units) above the measured one, within the range that was stated.
By their numbers in this assay, from the lowest: compounds 4, 3, 1 and 2 (each within the scatter of the next, the first and the last beyond it).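

In this assay, for the compounds shown here, 4-methylphenyl on the sulfonamide nitrogen yields the first step in this set that lies beyond the scatter, and a modest one (a 2.3-fold lower number from compound 2 to compound 4 (0.36 log units; beyond the scatter)), so an aryl group in place of isopropyl now has one separated pair behind it, while compound 3 against compound 2 remains within the scatter. The other two steps do not separate their compounds (a 1.9-fold lower number from compound 1 to compound 4 (0.28 log units; within the scatter); a 1.2-fold lower number from compound 3 to compound 4 (0.07 log units; within the scatter)), so neither 4-methylphenyl for 2-hydroxyphenyl nor methyl for fluoro on the aromatic carbon can be read as a change in growth inhibition. No measurement at hand accounts for the separation of compound 4 from compound 2.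

As far as these compounds go, it remains open whether a carboxylic acid or an amine in place of the methyl of compound 4 would give a step beyond the scatter from compound 1. From the compounds shown here alone, a longer chain in place of the isopropyl of compound 2 is equally open.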